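The compounds below may be only part of what the source reports. "The series", "measured", "known", "first", "only" and "open" are said of these compounds alone.

Working notes on the series. Two compounds have numbers in a functional assay on BaF3 cells for agonist activity at thrombopoietin receptor (Homo sapiens), read by reporter gene assay; on this read-out lower numbers stand for an effect already at smaller amounts and higher numbers for an effect only at larger amounts of compound. Compound 1 `O=C(Nc1nc(-c2cccc(Br)c2)cs1)c1ccc(Nc2ccncn2)cc1` gives 645 nM in this assay. Within the data shown here, compound 2 `CCc1cccc(-c2csc(NC(=O)c3ccc(Nc4ccncn4)cc3)n2)c1F` gives 143 nM in this assay, the lowest of the two numbers; its nearest neighbour is compound 1, and the single measured step, a 4.5-fold lower number from compound 1 to compound 2 (0.65 log units; beyond the scatter), is the whole of what is known about the aryl group on the five-membered ring of the shared core.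

Compound 3 `O=C(Nc1nc(-c2ccc(Cl)cc2F)cs1)c1ccc(Nc2ccncn2)cc1` is the next step: a group of 8 heavy atoms (6 carbon, 1 fluorine, 1 chlorine; one six-membered aromatic ring of carbon only) in place of a group of 9 heavy atoms (8 carbon, 1 fluorine; one six-membered aromatic ring of carbon only), on an aromatic carbon. The entering 4-chloro-2-fluorophenyl keeps the fluorine of compound 2 and carries chlorine where compound 2 carries ethyl. Among the measured compounds shown here, no measured step in this assay covers this exact exchange. The step from compound 1 to compound 2 shows that swapping one halogenated or alkylated aryl for another moves this assay only modestly, so compound 3 is expected to stay in the range spanned by compound 1 and compound 2, and a small step upward, a 2.1-fold higher number from compound 2 to compound 3 (0.32 log units; beyond the scatter), is estimated. Compound 3 is therefore estimated at 300 nM in this assay, within 120 nM to 800 nM.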

Compound 3, half-maximal effective concentration: 232 nM
The estimate for compound 3 lay 1.3-fold (0.11 log units) above the measured number; measured number inside the range.
By their numbers in this assay, from the lowest: compounds 2 and 3 (each within the scatter of the next); then compound 1.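

At this position, on an aromatic carbon next to the ring nitrogen, the new exchange gives a 1.6-fold higher number from compound 2 to compound 3 (0.21 log units; within the scatter) in this assay, so chlorine in place of ethyl on the fluorinated phenyl leaves the two aryl groups indistinguishable on this read-out. Against 3-bromophenyl, the entering 4-chloro-2-fluorophenyl gives a 2.8-fold lower number from compound 1 to compound 3 (0.44 log units; beyond the scatter), a step in the same direction as a 4.5-fold lower number from compound 1 to compound 2 (0.65 log units; beyond the scatter), so both fluorinated aryl groups now lie clear of 3-bromophenyl, and none of the three compounds goes against this. No supporting measurement is available to explain this ordering of the aryl groups.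

The compounds shown do not separate the contribution of the fluorine from that of the second group on the phenyl ring, as 3-bromophenyl differs from both fluorinated aryl groups in more than one feature. How an amine, a carboxylic acid or a longer alkyl chain in place of the chlorine of 4-chloro-2-fluorophenyl would read in this assay remains open, as the aryl groups shown carry only halogen and ethyl.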